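A few compounds are considered here, and "the series" means these few. Any claim that something is new, unique, unknown or untested is made for them only; others in the source may bear on it.

Working notes on the series. In a functional assay on HeLa cells (Homo sapiens) for cytotoxicity, read by MTT assay, with a stated time of 72 h (a lower number here means a stronger inhibitor, a higher number a weaker inhibitor), compound 1 `COc1cc2ncnc(Nc3ccc(F)c(Cl)c3)c2cc1NC(=O)/C=C/c1ccccc1[N+](=O)[O-]` stands at "not determined" (no result reported), and compound 3 `COc1cc2ncnc(Nc3ccc(F)c(Cl)c3)c2cc1NC(=O)/C=C/c1ccc(C#N)cc1` stands at "not determined" (no result reported), so neither offers a number to compare. Compound 2 `COc1ccc(OC)c(/C=C/C(=O)Nc2cc3c(Nc4ccc(F)c(Cl)c4)ncnc3cc2O[C@H]2CCOC2)c1` gives 26800 nM, the only numerical result so far. For the measured compounds named here, it therefore has no rank, and no measured pair shows how much a change in the aryl group moves this read-out.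

The next compound to be tested is compound 4 `O=C(/C=C/c1ccc(F)cc1Cl)Nc1cc2c(Nc3ccc(F)c(Cl)c3)ncnc2cc1O[C@H]1CCOC1`, which keeps the rest of compound 2 and alters only the aryl group on the chain. The difference is 2-chloro-4-fluorophenyl in place of 2,5-dimethoxyphenyl on a double-bonded chain carbon bound to a double-bonded chain carbon.

Going by the values given here, with no measured step to calibrate against, the expectation rests on compound 2 at 26800 nM as the sole anchor, and it stays cautious. A modest shift toward stronger inhibition is expected, of a size near the edge of the usual scatter, and no change at all would not be surprising. The expected move is a 1.8-fold lower number from compound 2 to compound 4 (0.25 log units; within the scatter), an estimate and not a measured result. For compound 4 the estimated value is 15000 nM, with an expected range from 4000 nM to 50000 nM.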

Compound 4, half-maximal inhibitory concentration: 37500 nM
The estimate for compound 4 lay 2.5-fold (0.40 log units) below the measured number; the range from low to high includes it.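

For the compounds shown here, the first measured step is a 1.4-fold higher number from compound 2 to compound 4 (0.15 log units; within the scatter) in this assay, at the aryl group on a double-bonded chain carbon bound to a double-bonded chain carbon. Replacing 2,5-dimethoxyphenyl, with its 2 hydrogen-bond acceptors and 10 heavy atoms, by 2-chloro-4-fluorophenyl, with 0 hydrogen-bond acceptors and 8 heavy atoms, therefore does not separate the two compounds in this read-out, and this single pair gives no sign that this exchange of ring substituents matters here. No accompanying measurement bears on the reason for this result.

As far as these compounds go, it remains open whether an aryl group carrying an amine or a carboxylic acid at this place would give a step beyond the scatter, or whether the two aryl groups read alike only within this narrow pair of substituent sets. Also open, from the compounds shown here alone, is what a longer chain, or a saturated chain in place of the double-bonded one, would do to the read-out when the rest of compound 2 is kept.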